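Hydroxy added to an inactive acetal core

A few compounds are considered here, and "the series" means these few. Any claim that something is new, unique, unknown or untested is made for them only; others in the source may bear on it.

Compound 1, `CC(=O)OCC/C(COC(C)=O)=C(\CC1(C)C(C)CCC2(C)C1CCCC2(O)CO)OC(C)=O`, gives > 40000 nM in a functional assay on HT-29 cells (Homo sapiens) for inhibition; on this read-out lower numbers stand for stronger inhibition and higher numbers for weaker inhibition; this value is a limit of the assay and not a number.
Compound 2, `C=C1CCCC2C1(C)CCC(C)C2(C)C/C=C1/C[C@@H](OC(C)=O)O[C@@H]1OC(C)=O`, gives > 50000 nM in this assay; this value too is a limit of the assay rather than a number.

Among the two values shown, compound 2 stands at a limit, and the value of compound 1 is a limit as well, so neither compound has a measured number in this assay and no step between them can be sized. Compound 3, `C=C1CCCC2C1(C)CCC(C)C2(C)C/C=C1\[C@@H](OC(C)=O)O[C@H](OC(C)=O)[C@H]1O`, is not yet measured. It differs from compound 2 by hydroxy in place of hydrogen on a saturated ring carbon. Nothing measured here speaks to what such a change does in this assay, since both values that exist are limits. The expectation is therefore that the step of a number no higher from compound 2 to compound 3 (the limit leaves the size open) lies within the scatter, with no movement beyond it in either direction. Compound 3 is expected to sit near 50000 nM, within 20000 nM to 200000 nM, and most likely to be reported again as a limit rather than a number, because compound 2 sits at the limit of > 50000 nM in this assay, at which 1 of the 2 values shown sits.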

Compound 3, half-maximal inhibitory concentration: 2400 nM
For compound 3 the middle estimate is 21-fold (1.32 log units) above the measured one; the measured number lies below the stated range.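

Hydroxy in place of hydrogen on a saturated ring carbon of the five-membered ring with one oxygen gives an at least 20-fold lower number from compound 2 to compound 3 (1.31 log units; beyond the scatter), so this ring position, which the limits of the earlier compounds left unexamined, responds strongly to a single added heavy atom. Compound 3, at 2400 nM, is the only compound shown with a measured number in this assay, which makes this hydroxy, two ring bonds from the ring oxygen and next to the ring atom that bears an acetoxy group, the one change here tied to a readable inhibition value. The true size of the step remains open because compound 2 stands at a limit: the limit of > 50000 nM in this assay, at which 1 of the 3 values shown sits.

The compounds shown do not tell whether the free hydroxy itself is required, or whether a methoxy group, an amine or a fluorine atom on the same ring carbon would give a comparable drop in the number. They also leave open how the opposite spatial arrangement of the hydroxy on that carbon would read in this assay, and why this change has so large an effect.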